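The compounds below may be only part of what the source reports. "The series", "measured", "known", "first", "only" and "open" are said of these compounds alone.

Measured so far in a functional assay on RKO cells (Homo sapiens) for inhibition, read by MTT assay, with a stated time of 48 h; on this read-out higher numbers stand for weaker inhibition and lower numbers for stronger inhibition:
Compound 1 `COc1ccc(N(C)c2nc(C)nc3ccccc23)cc1OCCC[Se]C#N` gives 799 nM
Compound 2 `COc1ccc(N(C)c2nc(C)nc3ccccc23)cc1C(=O)OCCC[Se]C#N` gives 1140 nM
Compound 3 `COc1ccc(N(C)c2nc(C)nc3ccccc23)cc1C(=O)NCC[Se]C#N` gives 1170 nM

Compound 3, at 1170 nM, cannot be separated from the other two, as the steps leading to it show: a 1.0-fold higher number from compound 2 to compound 3 (0.01 log units; within the scatter) and a 1.5-fold higher number from compound 1 to compound 3 (0.17 log units; within the scatter). The next compound is compound 4 `COc1ccc(N(C)c2nc(C)nc3ccccc23)cc1C(=O)OCCCC[Se]C#N`, and the structural change is a group of 8 heavy atoms (5 carbon, 1 nitrogen, 1 oxygen, 1 selenium; no ring) in place of a group of 6 heavy atoms (3 carbon, 2 nitrogen, 1 selenium; no ring), on a carbonyl carbon, on a carbonyl carbon whose other neighbours are: aromatic carbon.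

Within the data shown here, the closest guide is the one measured swap on this same carbonyl carbon, a 1.0-fold higher number from compound 2 to compound 3 (0.01 log units; within the scatter), and it is very small. The two changes made on an aromatic carbon, a 1.4-fold higher number from compound 1 to compound 2 (0.15 log units; within the scatter) and a 1.5-fold higher number from compound 1 to compound 3 (0.17 log units; within the scatter), also stayed within the scatter. Three compounds are thin evidence, but none of them points to a large shift in this assay, so no change beyond the scatter is expected. The expected step is a 1.1-fold lower number from compound 3 to compound 4 (0.03 log units; within the scatter). Compound 4 is estimated at 1100 nM, with an expected range from 550 nM to 2200 nM.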

Compound 4, half-maximal inhibitory concentration: 1020 nM
The estimate for compound 4 lay 1.1-fold (0.03 log units) above the measured number; measured number inside the range.
By their numbers in this assay, from the lowest: compounds 1, 4, 2 and 3 (each within the scatter of the next).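

In this assay, replacing the amide-linked chain on the carbonyl carbon with a longer ester-linked one removes the amide hydrogen yet gives a 1.1-fold lower number from compound 3 to compound 4 (0.06 log units; within the scatter), so this larger swap at this position still produces no separable change. The new compound also isolates chain length on the ester, where a longer saturated chain gives a 1.1-fold lower number from compound 2 to compound 4 (0.05 log units; within the scatter), while the change on the aromatic carbon gives a 1.3-fold higher number from compound 1 to compound 4 (0.11 log units; within the scatter), so all four compounds remain inseparable in this assay. No measurement shown explains why these changes leave the number within the scatter.

From the compounds shown here alone, it remains open whether a much longer chain, or a shorter one on the ester, would move the number beyond the scatter. The same is true of sulfur in place of selenium, or of an amine or a carboxylic acid at the chain end.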